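Two amides, one ring swapped

The source may report more compounds than this note shows. Statements on the series, on what has been measured and on what is new or still open speak of the compounds shown alone.

Measured so far in a functional assay on PC-3 cells (Homo sapiens) for inhibition, read by sulforhodamine B assay, with a stated time of 72 h; a lower number here means a stronger inhibitor, a higher number a weaker inhibitor
- Compound 1 `Nc1sc(-c2ccc(Cl)cc2)c(-c2ccc(Cl)cc2)c1C(=O)N1CCCCC1=O` gives 4940 nM
- Compound 2 `Nc1sc(-c2ccc(Cl)cc2)c(-c2ccc(Cl)cc2)c1C(=O)NC1CCCCC1` gives 7300 nM

Compound 2, at 7300 nM in these measurements, sits within the usual scatter of compound 1. Compound 3 `Nc1sc(-c2ccc(Cl)cc2)c(-c2ccc(Cl)cc2)c1C(=O)Nc1ccccc1` keeps the shared core and carries phenyl in place of cyclohexyl on an amide-type nitrogen. For the measured compounds named here, only one measured step bears on this, a swap of the group on a carbonyl carbon (a 1.5-fold higher number from compound 1 to compound 2 (0.17 log units; within the scatter)), and it stayed within the scatter. That single step is thin guidance, so no change beyond the scatter is expected in this assay for this swap. Compound 3 is estimated at 6000 nM (expected range 2500 nM to 15000 nM). The expected step is small (a 1.2-fold lower number from compound 2 to compound 3 (0.09 log units; within the scatter)).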

Compound 3, half-maximal inhibitory concentration: > 50000 nM
Compound 3 ended at the assay's limit (the forecaster's own chance of this, stated with the estimate: 10%); middle value at least 8.3-fold (0.92 log units) away from the limit.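

In this assay, this position on the amide-type nitrogen proves sensitive: phenyl in place of cyclohexyl, a ring for a ring with the same count of heavy atoms, gives an at least 6.8-fold higher number from compound 2 to compound 3 (0.83 log units; beyond the scatter), although the earlier swap stayed within the scatter. Anilino in place of 2-oxopiperidin-1-yl gives an at least 10-fold higher number from compound 1 to compound 3 (1.00 log units; beyond the scatter). The value of compound 3 is a limit of the assay, not a number: the limit of > 50000 nM in this assay, at which 1 of the 3 values shown sits.

The compounds shown leave open whether benzyl on the same nitrogen would behave like cyclohexyl or like phenyl.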